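A methyl replaces a fluorophenyl on the piperazine nitrogen

The source may hold more compounds than are shown below. What is called first, only, known or untested is meant among the compounds shown, and "the series" means these compounds.

The series rests on a shared core carrying a methylsulfonyl and a nitro group, tested in an assay on isolated protein for inhibition of thyroid hormone receptor beta (Homo sapiens), read by fluorescence polarization; on this read-out higher numbers stand for weaker inhibition and lower numbers for stronger inhibition. Compound 1 `CC(C)N(C(=O)CNC(=O)c1ccc(S(C)(=O)=O)c([N+](=O)[O-])c1)C(C)C` carries a diisopropyl amide; in this assay compound 1 gives only a limit of > 60000 nM. Compound 2 `CS(=O)(=O)c1ccc(C(=O)NCC(=O)N2CCN(c3ccccc3F)CC2)cc1[N+](=O)[O-]` carries a piperazine bearing a 2-fluorophenyl on its amine nitrogen; in this assay compound 2 likewise gives only a limit of > 60000 nM. Both values therefore sit at the same edge, namely (the limit of > 60000 nM in this assay, at which 2 of the 2 values shown sit), so compound 2 stands nowhere above the other compound on the numbers known.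

Compound 3 `CN1CCN(C(=O)CNC(=O)c2ccc(S(C)(=O)=O)c([N+](=O)[O-])c2)CC1` has not yet been measured. It differs from compound 2 by methyl in place of 2-fluorophenyl on an amine nitrogen in a ring. Among the measured compounds shown here, no measured pair shows what such a change does, and the two compounds known give no number that a step could start from. The step from compound 2 to compound 3 is therefore expected to stay within the scatter, as a step that the limit leaves unreadable from compound 2 to compound 3. Compound 3 is estimated at 100000 nM, ranging from 30000 nM to 300000 nM, and most likely it will again return only a limit in this assay.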

Compound 3, half-maximal inhibitory concentration: > 60000 nM
Compound 3: no number, only a limit; the forecaster's own chance of this, stated with the estimate: 85%; the middle value is on the limit's open side.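

Neither the step from compound 2 to compound 3 nor the step from compound 1 to compound 3 can be read in this assay, since each compound returns only a limit: the limit of > 60000 nM in this assay, at which 3 of the 3 values shown sit.

The compounds shown leave open what either exchange does to inhibition, and whether any compound on the shared core gives a measurable value in this assay.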